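The source may hold more compounds than are shown below. What is called first, only, known or untested is meant among the compounds shown, and "the series" means these compounds.

In an ADME assay on HepG2 2.2.15 cells (Homo sapiens) for cytotoxicity, read by CCK-8 assay, with a stated time of 8 days (on this read-out higher numbers stand for lower toxicity in this test and lower numbers for higher toxicity in this test), compound 1 `COc1ccc(-c2cc(NC(=O)c3ccccc3O)c[nH]c2=O)cc1` stands at > 100000 nM as a limit of the assay and not a number. Compound 2 `COc1ccc(-c2cc(NC(=O)c3ccc(OC)cc3O)c[nH]c2=O)cc1` gives 49900 nM and compound 3 `COc1ccc(-c2cc(NC(=O)c3ccc(Cl)cc3O)c[nH]c2=O)cc1` gives 50500 nM in the same test. These two numbers sit level, with a 1.0-fold higher number from compound 2 to compound 3 (0.01 log units; within the scatter) separating them. Compound 4 `COc1ccc(-c2cc(NC(=O)c3ccc(C)cc3O)c[nH]c2=O)cc1` has methyl in place of chloro on an aromatic carbon, meta to a hydroxy group and para to a large group, counted as methyl in place of chloro on an aromatic carbon against compound 3. Two further measured steps bear on this change: an at least 2.0-fold lower number from compound 1 to compound 2 (0.30 log units; that floor lies within the scatter) for methoxy in place of hydrogen and an at least 1.9-fold lower number from compound 1 to compound 3 (0.29 log units; that floor lies within the scatter) for chloro in place of hydrogen. Since methoxy in compound 2 and chloro in compound 3 gave matching values, with compound 3 at 50500 nM as the anchor, methyl is expected to leave the number within the scatter. The expected change is a 1.0-fold lower number from compound 3 to compound 4 (0.00 log units; within the scatter) in this assay and no real shift in either direction. For compound 4 the estimate is 50000 nM with an expected range of 25000 nM to 100000 nM in this assay when it is measured.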

Compound 4, half-maximal cytotoxic concentration: 46100 nM
Beside the measured number, compound 4's estimate is 1.1-fold (0.04 log units) above it, and the stated range covers the measured number.
By their numbers in this assay, from the lowest: compounds 4, 2 and 3 (each within the scatter of the next). At a limit, above all of these: compound 1.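

In this assay, methyl on this aromatic carbon, meta to a hydroxy group and para to a large group, cannot be told apart from chloro or methoxy, with a 1.1-fold lower number from compound 3 to compound 4 (0.04 log units; within the scatter) and a 1.1-fold lower number from compound 2 to compound 4 (0.03 log units; within the scatter). Among the compounds shown here, replacing hydrogen with methyl gives an at least 2.1-fold lower number from compound 1 to compound 4 (0.33 log units; beyond the scatter), so this is the first step from compound 1 whose floor clears the scatter, whereas the floors for methoxy and chloro stayed within it. Compound 1 stands at a limit of the assay and not a number, so the true size of this step stays unknown: the limit of > 100000 nM in this assay, at which 1 of the 4 values shown sits.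

The compounds shown leave open whether an amine, a carboxylic acid or a longer chain on this carbon would stay level with methyl, chloro and methoxy. They also leave open how far compound 1 really lies from compound 4.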